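The source may report more compounds than this note shows. Statements on the series, on what has been measured and on what is new or still open speak of the compounds shown alone.

Values so far in a functional assay on GC-2 cells (Mus musculus) for cytotoxicity, read by MTT assay, with a stated time of 72 h (a lower number here means a stronger inhibitor, a higher number a weaker inhibitor), are these
compound 1 `Nc1nc(NC2CCCCC2)sc1C(=O)c1cccnc1` - "not determined" (no result reported)
compound 2 `Nc1nc(Nc2ccc(S(N)(=O)=O)cc2)sc1C(=O)c1ccccc1[N+](=O)[O-]` - 9000 nM

Among the compounds with values here, compound 2 at 9000 nM holds the only number, so it cannot yet be ranked against any other compound. Compound 3 `COc1cccc(C(=O)c2sc(Nc3ccc(S(N)(=O)=O)cc3)nc2N)c1` is still to be measured in this assay and differs from compound 2 as follows: 3-methoxyphenyl in place of 2-nitrophenyl on a carbonyl carbon with 3-methoxyphenyl in place of 2-nitrophenyl on a carbonyl carbon. Within the data shown here, no measured pair shows what such a change does, so the sole anchor is compound 2 at 9000 nM and no direction can be argued from the data. The expected step of a 1.3-fold lower number from compound 2 to compound 3 (0.11 log units; within the scatter) stays within the scatter in either direction. For compound 3 the estimated value is 7000 nM within an expected range of 2000 nM to 25000 nM for now.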

Compound 3, half-maximal inhibitory concentration: 11000 nM
Beside the measured number, compound 3's estimate is 1.6-fold (0.20 log units) below it; the measured number falls inside the stated range.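

In this assay, 3-methoxyphenyl in place of 2-nitrophenyl on a carbonyl carbon gives a 1.2-fold higher number from compound 2 to compound 3 (0.09 log units; within the scatter), the first step read at this place, and it lies within the scatter. The two groups therefore cannot be told apart here: the exchange of the nitro-bearing aryl group for the methoxy-bearing one leaves no readable difference in this cytotoxicity read-out. No supporting data bear on this result.

Still open, from the compounds shown here alone, is whether any group on this carbonyl carbon can move the number beyond the scatter, since a single step between two substituted phenyl groups sets no range for the place. A carboxylic acid or an amine on the phenyl ring, or a longer alkyl chain in place of that ring, would test this more widely.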